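Chain extension on the ester tail: compound 3 to compound 4

A few compounds are considered here, and "the series" means these few. Any claim that something is new, unique, unknown or untested is made for them only; others in the source may bear on it.

Compound 3 `CCCCCCCCCOC(=O)CCC(=O)N1CCN(CCCOc2cc3c(Nc4ccc(F)c(Cl)c4)ncnc3cc2OC)CC1` gives 90% in a functional assay on A549 cells (Homo sapiens) for cytotoxicity, read by MTT assay, with a stated time of 24 h, tested at 10 uM (a higher number here means a weaker effect of the compound at the concentration tested, a lower number a stronger effect), the highest of the three numbers, though its steps to both neighbours lie within the scatter: compound 2 `CCCCCCCCOC(=O)CCC(=O)N1CCN(CCCOc2cc3c(Nc4ccc(F)c(Cl)c4)ncnc3cc2OC)CC1` gives 87.3% and compound 1 `CCCCCOC(=O)CCC(=O)N1CCN(CCCOc2cc3c(Nc4ccc(F)c(Cl)c4)ncnc3cc2OC)CC1` gives 87.1%. Compound 4 `CCCCCCCCCCOC(=O)CCC(=O)N1CCN(CCCOc2cc3c(Nc4ccc(F)c(Cl)c4)ncnc3cc2OC)CC1` differs from compound 3 by methyl in place of hydrogen on a saturated chain carbon, nine bonds along the chain from an oxygen next to a carbonyl group. Among the compounds with values here, the steps that bear on this change are a number 0.2 percentage points higher from compound 1 to compound 2 (within the scatter), a number 2.9 percentage points higher from compound 1 to compound 3 (within the scatter) and a number 2.7 percentage points higher from compound 2 to compound 3 (within the scatter), each within the scatter; lengthening the chain on the oxygen next to a carbonyl group has so far moved nothing beyond the scatter. Compound 4 is therefore expected to stay close to compound 3, with an estimated step of no change at the digits printed from compound 3 to compound 4 (within the scatter). The estimate for compound 4 is 90%, expected between 82% and 96%.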

Compound 4, a percentage reported as activity, at one concentration (the size of the read-out at that concentration, not a potency): 95.7%
Beside the measured number, compound 4's estimate is 5.7 percentage points below it, within the range that was stated.
By their numbers in this assay, from the lowest: compounds 1, 2, 3 and 4 (each within the scatter of the next).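

Methyl in place of hydrogen at this position, nine bonds along the chain from an oxygen next to a carbonyl group, reads as a number 5.7 percentage points higher from compound 3 to compound 4 (within the scatter) in this assay and extends the flat picture to the longest chain shown. The shorter esters give a number 8.4 percentage points higher from compound 2 to compound 4 (within the scatter) and a number 8.6 percentage points higher from compound 1 to compound 4 (within the scatter) so the whole span of chains shown stays inside the scatter. No supporting data bear on these numbers.

On these data alone, whether a longer chain would move the number beyond the scatter stays open. So does the effect of a carboxylic acid or an amine in place of the ester tail.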